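A Third Chloro Added to a Series Sitting at the Limit

The compounds below may be only part of what the source reports. "The series", "measured", "known", "first", "only" and "open" are said of these compounds alone.

All three measured compounds were examined in a functional assay on HepG2 cells (Homo sapiens) for antiproliferative activity, read by MTT assay, with a stated time of 48 h; on this read-out lower numbers stand for stronger inhibition and higher numbers for weaker inhibition.
Compound 1, `Cc1cccc(-n2nncc2CN2C(=O)C3(C(C#N)=C(N)Oc4c(N)cc5nc6ccccc6nc5c43)c3ccccc32)c1`: in this assay compound 1 reports only a limit, > 50000 nM.
Compound 2, `N#CC1=C(N)Oc2c(N)cc3nc4ccccc4nc3c2C12C(=O)N(Cc1cnnn1-c1cccc(Br)c1)c1ccccc12`: in this assay compound 2 reports only a limit, > 50000 nM.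
Compound 3, `N#CC1=C(N)Oc2c(N)cc3nc4ccccc4nc3c2C12C(=O)N(Cc1cnnn1-c1ccc(Cl)cc1Cl)c1ccccc12`: in this assay compound 3 reports only a limit, > 50000 nM.

Compound 3 therefore stands at the limit of the assay, the same place where every value shown sits, as the limit of > 50000 nM in this assay, at which 3 of the 3 values shown sit, records. None of the steps between the measured compounds can be sized: the step that the two limits leave unreadable from compound 1 to compound 2, the step that the two limits leave unreadable from compound 1 to compound 3 and the step that the two limits leave unreadable from compound 2 to compound 3 are all hidden behind the limit, so neither direction nor magnitude is known for any of them.

Compound 4, `N#CC1=C(N)Oc2c(N)cc3nc4ccccc4nc3c2C12C(=O)N(Cc1cnnn1-c1c(Cl)cc(Cl)cc1Cl)c1ccccc12`, differs from compound 3 by chloro in place of hydrogen on an aromatic carbon; cut one bond further out, the change reads 2,4-dichlorophenyl to 2,4,6-trichlorophenyl. The most closely related measured step, a step that the two limits leave unreadable from compound 2 to compound 3, also exchanges one halogenated phenyl for another and is unreadable. With no readable step anywhere in the set, no direction can be expected for compound 4 beyond the scatter, and compound 4 is expected to remain at the limit, the step that the limit leaves unreadable from compound 3 to compound 4 being an expectation of no change. For compound 4 the estimate is 60000 nM, with an expected range from 20000 nM to 200000 nM.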

Compound 4, half-maximal inhibitory concentration: 37800 nM
Compound 4: middle estimate off by 1.6-fold (0.20 log units), on the high side; low and high end bracket the measured number.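

In this assay, going by these compounds alone, compound 4 gives 37800 nM, a number rather than a limit, so chloro in place of hydrogen on an aromatic carbon, ortho to a large group and meta to two chloro groups, is the one change at this ring with a step that can be read in part: an at least 1.3-fold lower number from compound 3 to compound 4 (0.12 log units; that floor lies within the scatter). Exchanging the whole aryl group for 2,4,6-trichlorophenyl can now be read in the same partial way, as an at least 1.3-fold lower number from compound 2 to compound 4 (0.12 log units; that floor lies within the scatter) and as an at least 1.3-fold lower number from compound 1 to compound 4 (0.12 log units; that floor lies within the scatter). Each of these is only a floor within the scatter, so compound 4 has a number but its true distance from the other three stays unfixed, as they remain limits: the limit of > 50000 nM in this assay, at which 3 of the 4 values shown sit.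

On these data alone, the steps among compound 1, compound 2 and compound 3 still cannot be read, and how far any of them lies from compound 4 remains unknown. As far as these compounds go, it also stays open how a bromo, a methoxy or an amine on this same carbon would read, and whether chloro at this place would give a number on a ring other than the 2,4-dichlorophenyl of compound 3.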